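Fluoro for ethoxycarbonyl on the pendant phenyl ring

This account rests on a few compounds, and the source may have more. Where it says the series, first, only, none or still open, it means among the compounds named here.

Measured so far in a functional assay on MCF7 cells (Homo sapiens) for inhibition, read by CCK-8 assay, with a stated time of 48 h; on this read-out higher numbers stand for weaker inhibition and lower numbers for stronger inhibition:
compound 1 `COc1ccc(-c2cc3nccc(-c4cc(OC)c(OC)c(OC)c4)n3n2)cc1N`: 27 nM
compound 2 `COc1cc(-c2ccnc3cc(-c4ccc5cnn(C)c5c4)nn23)cc(OC)c1OC`: 279 nM
compound 3 `CCOC(=O)c1ccc(-c2cc3nccc(-c4cc(OC)c(OC)c(OC)c4)n3n2)cc1`: > 10000 nM

Compound 3 stands apart from the other two. In this assay compound 3 gives only a limit, > 10000 nM, not a number; it sits at the limit of > 10000 nM in this assay, at which 1 of the 3 values shown sits. Among the measured compounds shown here, the one measured step at this part of the shared core, a 10-fold higher number from compound 1 to compound 2 (1.01 log units; beyond the scatter), shows that swapping the aryl group attached there moves the read-out by a large amount, so the identity of this group matters for compound 1 and compound 2 alike.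

Compound 4 `COc1cc(-c2ccnc3cc(-c4ccc(F)cc4)nn23)cc(OC)c1OC` is the next member, not yet measured. It differs from compound 3 by fluoro in place of ethoxycarbonyl on an aromatic carbon, the change sitting on an aromatic carbon of a six-membered aromatic ring of carbon only, para to a large group. The ethoxycarbonyl leaves and a single fluoro enters.

For the measured compounds named here, no measured step describes exactly this change; the step between compound 1 and compound 2 only shows that such substitutions are large. Because compound 3 sits at the limit of > 10000 nM in this assay, at which 1 of the 3 values shown sits, any numeric result for compound 4 would mean a move to a lower number. Compound 4 is expected at 2500 nM, in the range 300 nM to 10000 nM. For compound 4 the expected step is an at least 4.0-fold lower number from compound 3 to compound 4 (0.60 log units; beyond the scatter), with a real chance that only a limit is returned again.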

Compound 4, half-maximal inhibitory concentration: 1280 nM
For compound 4 the middle estimate is 2.0-fold (0.29 log units) above the measured one, within the range that was stated.
By their numbers in this assay, from the lowest: compound 1; then compound 2; then compound 4. At a limit, above all of these: compound 3.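

In this assay compound 3 gives > 10000 nM, which is a limit and not a number: the limit of > 10000 nM in this assay, at which 1 of the 4 values shown sits. Among the compounds shown here, replacing the ethoxycarbonyl with a single fluoro on this aromatic carbon gives a measurable value, an at least 7.8-fold lower number from compound 3 to compound 4 (0.89 log units; beyond the scatter), so a para substituent on the pendant phenyl ring can decide whether the read-out leaves the limit at all, a point the earlier compounds could not show. The 4-fluorophenyl group still gives weaker inhibition than either of the other two aryl groups, with a 4.6-fold higher number from compound 2 to compound 4 (0.66 log units; beyond the scatter) and a 47-fold higher number from compound 1 to compound 4 (1.68 log units; beyond the scatter), which sets the order of the three groups as 3-amino-4-methoxyphenyl, then 1-methyl-1H-indazol-6-yl, then 4-fluorophenyl.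

The compounds shown leave open whether the move away from the limit comes from losing the ethoxycarbonyl or from gaining the fluoro, as an unsubstituted phenyl at this place would separate the two. Also open, on these data alone, is how a carboxylic acid or a primary amide in the same para place would read out, and whether the amine or the methoxy of compound 1 carries its lead over compound 4.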